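Aryl ether variations on a bicyclic glutamate receptor scaffold

The compounds below may be only part of what the source reports. "The series", "measured", "known", "first", "only" and "open" are said of these compounds alone.

Measured compounds:
- compound 1, `CO[C@@H]1C[C@@H]2[C@H]([C@]1(N)C(=O)O)[C@@]2(F)C(=O)O`: 39.2 nM
- compound 2, `N[C@]1(C(=O)O)[C@H]2[C@@H](C[C@H]1OCc1ccccc1Cl)[C@]2(F)C(=O)O`: 4.99 nM
- compound 3, `N[C@]1(C(=O)O)[C@H]2[C@@H](C[C@H]1OCc1cc(F)ccc1F)[C@]2(F)C(=O)O`: 14.4 nM

In an assay on CHO cells for binding affinity to metabotropic glutamate receptor 2 (Rattus norvegicus) (on this read-out lower numbers stand for stronger inhibition and higher numbers for weaker inhibition), compound 3 sits second highest of the three numbers, nearer to compound 1 than to compound 2. The step of a 2.7-fold lower number from compound 1 to compound 3 (0.43 log units; beyond the scatter) shows what the 2,5-difluorophenyl group brings over hydrogen, while a 7.9-fold lower number from compound 1 to compound 2 (0.90 log units; beyond the scatter) shows a larger gain for the 2-chlorophenyl group, and a 2.9-fold higher number from compound 2 to compound 3 (0.46 log units; beyond the scatter) separates the two aryl groups from each other.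

Compound 4, `N[C@]1(C(=O)O)[C@H]2[C@@H](C[C@H]1OCc1ccc(F)c(Cl)c1)[C@]2(F)C(=O)O`, carries a third aryl group: 3-chloro-4-fluorophenyl in place of 2,5-difluorophenyl on a saturated chain carbon bound to an oxygen on a saturated carbon. Among the measured compounds shown here, no measured step compares a 3-chloro-4-fluorophenyl group with any other, so the only guide is that both aryl groups tried so far lowered the number relative to compound 1 and differed modestly from each other. Compound 4 is therefore expected to land within the span set by compound 2 and compound 3, most likely close to compound 3, with the step of a 1.4-fold lower number from compound 3 to compound 4 (0.16 log units; within the scatter) estimated to be small. The estimate for compound 4 in this assay is 10 nM, with a range from 4 nM to 30 nM.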

Compound 4, inhibition constant: 3.57 nM
Compound 4: middle estimate off by 2.8-fold (0.45 log units), on the high side, outside the stated range (below it).
By their numbers in this assay, from the lowest: compounds 4 and 2 (each within the scatter of the next); then compound 3; then compound 1.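

In this assay, the aryl group at this place proves able to shift the number even with the heavy-atom count unchanged: exchanging 2,5-difluorophenyl for 3-chloro-4-fluorophenyl gives a 4.0-fold lower number from compound 3 to compound 4 (0.61 log units; beyond the scatter). The two chlorine-bearing groups cannot be told apart, with a 1.4-fold lower number from compound 2 to compound 4 (0.15 log units; within the scatter), so among these three aryl groups only 2,5-difluorophenyl stands apart, and the chlorine can occupy different places in the group's name without a separable change. Against hydrogen, the new group gives an 11-fold lower number from compound 1 to compound 4 (1.04 log units; beyond the scatter), the first step at this place to reach a large size.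

Nothing available explains why these aryl groups differ. Open too, on these data alone, is whether an aryl ring is needed at all, or whether an amine, a carboxylic acid or a longer chain on this carbon would give a comparable number.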